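Aryl swaps on the amine of a shared core

This account rests on a few compounds, and the source may have more. Where it says the series, first, only, none or still open, it means among the compounds named here.

Measured so far:
Compound 1 `O=C1C=C(Nc2cccc(Cl)c2)C(=O)c2c1nc1n2[C@H]2OC[C@@H](O)[C@H]2OC1` gives 4690 nM.
Compound 2 `O=C1C=C(NC2CCCCC2)C(=O)c2c1nc1n2[C@H]2OC[C@@H](O)[C@H]2OC1` gives > 16000 nM, which is a limit of the assay, not a number.
Compound 3 `CCOc1ccc(NC2=CC(=O)c3nc4n(c3C2=O)[C@H]2OC[C@@H](O)[C@H]2OC4)cc1` gives 3210 nM.

All three were tested in a functional assay on ECa-109 cells for inhibition, with ECa-109 cell line (Homo sapiens) as the target, read by sulforhodamine B assay; on this read-out lower numbers stand for stronger inhibition and higher numbers for weaker inhibition. Compound 3 has the lowest number given, though compound 1 sits within the scatter of it. Compound 4 `O=C1C=C(Nc2ccc(Br)cc2)C(=O)c2c1nc1n2[C@H]2OC[C@@H](O)[C@H]2OC1` differs from compound 3 by bromo in place of ethoxy on an aromatic carbon. Among the compounds with values here, the only aryl-to-aryl step seen, a 1.5-fold lower number from compound 1 to compound 3 (0.16 log units; within the scatter), stayed within the scatter; the big change came only on leaving the aryl ring altogether, an at least 3.4-fold higher number from compound 1 to compound 2 (0.53 log units; beyond the scatter). Since compound 4 keeps an aryl ring, the expected step of a 1.2-fold higher number from compound 3 to compound 4 (0.10 log units; within the scatter) is small, likely within the scatter. Compound 4 is therefore estimated at 4000 nM, between 1500 nM and 12000 nM.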

Compound 4, half-maximal inhibitory concentration: 2850 nM
Estimate against measurement, compound 4: 1.4-fold (0.15 log units) above; the range from low to high includes it.
By their numbers in this assay, from the lowest: compounds 4, 3 and 1 (each within the scatter of the next). At a limit, above all of these: compound 2.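

Bromo in place of ethoxy on an aromatic carbon leaves the result in this assay within the scatter, with a 1.1-fold lower number from compound 3 to compound 4 (0.05 log units; within the scatter), and a 1.6-fold lower number from compound 1 to compound 4 (0.22 log units; within the scatter) shows the same, so a third aryl group sits with the other two. Only the cyclohexyl group stands apart, with an at least 5.6-fold lower number from compound 2 to compound 4 (0.74 log units; beyond the scatter). That step starts from a limit of the assay, not a number: the limit of > 16000 nM in this assay, at which 1 of the 4 values shown sits.

From the compounds shown here alone, what stays open is how a carboxylic acid or an amine on the aromatic ring would read, and whether a short alkyl chain on the amine nitrogen would behave like cyclohexyl.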